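A few compounds are considered here, and "the series" means these few. Any claim that something is new, unique, unknown or untested is made for them only; others in the source may bear on it.

Series notes. Going by the values given here, compound 1 `CCCCc1nc(C(C)C)c(CC(=O)OC)c(=O)n1Cc1ccc(-c2ccccc2-c2noc(=O)[nH]2)cc1` and compound 2 `CCCCc1nc(C)c(CC(=O)OC(C)C)c(=O)n1Cc1ccc(-c2ccccc2-c2noc(=O)[nH]2)cc1` share one core and differ in two places at once, so no single-change step between them can be read. In an ADME assay on microsomes from liver (Homo sapiens) for metabolic stability, with a stated time of 30 min (a higher number here means that more of the compound is left, a lower number that less of the compound is left), compound 1 gives 10.5%. In this assay compound 2 gives 17.5%; the two numbers lie within the usual scatter of each other, so compound 2 stands level with compound 1 rather than apart from it, and in both cases only a small part of the compound is left after the stated time.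

Compound 3 `CCCCc1nc(C)c(CC(=O)OCC2CCCCC2)c(=O)n1Cc1ccc(-c2ccccc2-c2noc(=O)[nH]2)cc1` is the next member and has not yet been run in this assay. Its difference from compound 2 is cyclohexylmethyl in place of isopropyl on an oxygen next to a carbonyl group, with the rest of the molecule unchanged. Among the compounds with values here, no measured pair carries a change of this kind, so the expectation rests on the number of compound 2 and on the change alone. The expected direction is downward. The step of a number 9.5 percentage points lower from compound 2 to compound 3 (within the scatter) is expected to be small in absolute terms and within the scatter. Since compound 2 already gives 17.5%, there is little room for a large fall. Compound 3 is estimated at 8%, with an expected range from 2% to 20%.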

Compound 3, percent of the compound remaining: 11.5%
Compound 3: the middle estimate sits 3.5 percentage points below what was measured; the measured number falls inside the stated range.
By their numbers in this assay, from the lowest: compounds 1, 3 and 2 (each within the scatter of the next).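

Cyclohexylmethyl in place of isopropyl on an oxygen next to a carbonyl group gives a number 6 percentage points lower from compound 2 to compound 3 (within the scatter) as the first single-change reading at this position in this assay and the only one available so far. Going from 3 heavy atoms without a ring to 7 heavy atoms with one six-membered non-aromatic ring of carbon only therefore leaves compound 3 level with compound 2, and in both only a small part of the compound is left after the stated time. Nothing measured in this series bears on the reason for this result.

Compound 1 differs from compound 2 and from compound 3 in more than one place, so the steps that link it to them cannot be read. Still open, going by these compounds, is whether a different kind of group on the same oxygen, such as an aminoethyl chain or a chain ending in a carboxylic acid, would move the number in this assay beyond the scatter, or whether it too would stay level with compound 2.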